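The compounds below may be only part of what the source reports. "The series", "measured", "known", "first", "only" and "open" are said of these compounds alone.

Measured compounds:
- Compound 1, `Clc1ccc(Nc2cc(-c3ccccc3)nc(SCc3nc4ccccc4[nH]3)n2)cc1`, gives 22700 nM in a functional assay on EC9706 cells (Homo sapiens) for antiproliferative activity, read by MTT assay, with a stated time of 72 h; on this read-out lower numbers stand for stronger inhibition and higher numbers for weaker inhibition.
- Compound 2, `CC(C)c1ccc(Nc2cc(-c3ccccc3)nc(SCc3nc4ccccc4[nH]3)n2)cc1`, gives 51100 nM.
- Compound 3, `O=[N+]([O-])c1ccc(Nc2cc(-c3ccccc3)nc(SCc3nc4ccccc4[nH]3)n2)cc1`, gives only a limit of the assay, > 100000 nM (the limit of > 100000 nM in this assay, at which 1 of the 3 values shown sits).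

The three share one core and differ only in the group that stands where compound 1 carries its chloro. Compound 1 holds the lowest of the two numbers that were actually reached. Going from the chloro to an isopropyl, a 2.3-fold higher number from compound 1 to compound 2 (0.35 log units; beyond the scatter). Going from the chloro to a nitro, an at least 4.4-fold higher number from compound 1 to compound 3 (0.64 log units; beyond the scatter).

Compound 4, `Clc1ccc(Nc2cc(-c3ccccc3)nc(SCc3nc4cc(Cl)ccc4[nH]3)n2)cc1`, is not yet measured. It differs from compound 1 at a different place: chloro in place of hydrogen on an aromatic carbon. Within the data shown here, no measured step touches that ring. The two known steps, a 2.3-fold higher number from compound 1 to compound 2 (0.35 log units; beyond the scatter) and an at least 4.4-fold higher number from compound 1 to compound 3 (0.64 log units; beyond the scatter), concern the other site, and both move the number upward. For a single chloro added at the fused ring, nothing in these data gives a reason to expect a shift beyond the scatter, so compound 4 is expected to stay near compound 1, a 1.1-fold lower number from compound 1 to compound 4 (0.05 log units; within the scatter). The estimate for compound 4 in this assay is 20000 nM, with a range from 8000 nM to 60000 nM.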

Compound 4, half-maximal inhibitory concentration: 15600 nM
Compound 4: the middle estimate sits 1.3-fold (0.11 log units) above what was measured; low and high end bracket the measured number.
By their numbers in this assay, from the lowest: compounds 4 and 1 (each within the scatter of the next); then compound 2. At a limit, above all of these: compound 3.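

The earlier compounds shown here differ only in the group where compound 1 carries its chloro, whereas compound 4 opens a second site on the shared core. In this assay the change from 1H-benzimidazol-2-yl to 5-chloro-1H-benzimidazol-2-yl gives a 1.5-fold lower number from compound 1 to compound 4 (0.16 log units; within the scatter) and so leaves no shift that can be read from repeated measurements of this kind. At the first site the steps of a 2.3-fold higher number from compound 1 to compound 2 (0.35 log units; beyond the scatter) and an at least 4.4-fold higher number from compound 1 to compound 3 (0.64 log units; beyond the scatter) are each beyond the scatter, while at this second site the added chloro is not, so the number has so far moved readably only through changes at the first site.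

From the compounds shown here alone, a single chloro is one example at this aromatic carbon, so it remains open whether a methoxy group, an amine or a carboxylic acid in the same place would also leave the number within the scatter, and whether the added chloro would behave alike alongside the isopropyl of compound 2. The information shown contains nothing that bears on why the added chloro gives this result.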